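Swapping the heteroaryl on the sulfur of compound 3

The compounds below may be only part of what the source reports. "The series", "measured", "known", "first", "only" and "open" are said of these compounds alone.

Measured compounds:
- compound 1 `Cn1c(-c2ccc(NC(=O)CSc3nc4ccccc4o3)cc2)nc(-c2ccccc2)c1-c1ccccc1`: 81.5%
- compound 2 `Cn1c(-c2ccc(NC(=O)CSc3nc4cc(Cl)ccc4o3)cc2)nc(-c2ccccc2)c1-c1ccccc1`: 79.6%
- compound 3 `Cn1c(-c2ccc(NC(=O)CSc3nc4ccccc4s3)cc2)nc(-c2ccccc2)c1-c1ccccc1`: 82.7%

In a functional assay on HT-29 cells (Homo sapiens) for cytotoxicity, read by MTT assay, with a stated time of 24 h, tested at 80 ug/mL (a lower number here means a weaker effect, a higher number a stronger effect of the compound at the concentration tested), compound 3 gives the highest of the three numbers, but its neighbours sit close: the step of a number 1.2 percentage points higher from compound 1 to compound 3 (within the scatter) and the step of a number 3.1 percentage points higher from compound 2 to compound 3 (within the scatter) are both within the scatter, so no order among the three can be claimed. Compound 4 `Cn1nnnc1SCC(=O)Nc1ccc(-c2nc(-c3ccccc3)c(-c3ccccc3)n2C)cc1` differs from compound 3 in the heteroaryl that sits on the sulfur: 1-methyl-1H-tetrazol-5-yl in place of 1,3-benzothiazol-2-yl on a sulfur.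

For the measured compounds named here, two measured steps bear on this kind of exchange. Replacing the benzoxazolyl of compound 1 by benzothiazolyl, a number 1.2 percentage points higher from compound 1 to compound 3 (within the scatter), and replacing the chlorinated benzoxazolyl of compound 2, a number 3.1 percentage points higher from compound 2 to compound 3 (within the scatter), each left the read-out in this assay essentially where it was. Going by the values given here, the change to a 1-methyl-1H-tetrazol-5-yl is larger than either of those, and no measured compound carries a ring of this kind, so the expectation rests on the observation that the heteroaryl on the sulfur has so far not moved the number. Compound 4 is therefore expected to show a step of a number 6.7 percentage points lower from compound 3 to compound 4 (within the scatter), which is estimated to stay within the scatter. Compound 4 is expected to give 76% in this assay, with a range from 55% to 90%.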

Compound 4, a percentage reported as activity, at one concentration (the size of the read-out at that concentration, not a potency): 89%
Estimate against measurement, compound 4: 13 percentage points below; the measured number falls inside the stated range.
By their numbers in this assay, from the lowest: compounds 2, 1, 3 and 4 (each within the scatter of the next).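

In this assay, the step of a number 6.3 percentage points higher from compound 3 to compound 4 (within the scatter), the step of a number 7.5 percentage points higher from compound 1 to compound 4 (within the scatter) and the step of a number 9.4 percentage points higher from compound 2 to compound 4 (within the scatter) all stay within the scatter. The earlier compounds shown here carried only two-ring groups on this sulfur, whereas compound 4 shows that one five-membered aromatic ring with 4 hetero atoms, 1-methyl-1H-tetrazol-5-yl, can take that place with no change that can be read, so the tolerance at this position extends beyond the benzoxazolyl and benzothiazolyl groups. No measurement here offers an explanation for this tolerance.

From the compounds shown here alone, whether it holds for a non-aromatic group on the sulfur, such as a piperidine or a short chain ending in a carboxylic acid, remains open. Going by these compounds, with a read-out at one concentration only, it also remains open whether the four compounds differ in potency.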